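The compounds below may be only part of what the source reports. "The series", "measured", "known", "first", "only" and "open" are said of these compounds alone.

Compound 1, `COc1ccc(-c2cc(=O)c3c(OC)cc(OC)cc3[nH]2)cc1`, in a functional assay on SUP-B15 cells (Homo sapiens) for antiproliferative activity, with a stated time of 72 h (on this read-out lower numbers stand for an effect already at smaller amounts and higher numbers for an effect only at larger amounts of compound), gives > 62000 nM, which is a limit of the assay and not a number.
Compound 2, `COc1ccc(-c2cc(=O)c3c(OC)cc(OC)cc3n2Cc2ccccc2)cc1`, in this assay gives > 34400 nM, again a limit.
Compound 3, `COc1ccc(-c2cc(=O)c3c(OC)cc(OC)cc3n2S(=O)(=O)c2cc(Cl)cc(Cl)c2O)cc1`, in this assay gives > 37900 nM, also a limit.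

Compound 3 therefore stands at the limit of > 37900 nM in this assay, at which 1 of the 3 values shown sits, and the other two measured compounds likewise sit at limits, so none of the three supplies a number on which compound 3 could be ranked. Within the data shown here, the only pair that differs in one place is compound 1 and compound 2, and their step that the two limits leave unreadable from compound 1 to compound 2 cannot be read because both ends are limits.

Compound 4, `COc1ccc(-c2cc(=O)c3c(OC)cc(OC)cc3n2S(=O)(=O)c2ccc(Br)s2)cc1`, has not yet been measured. It differs from compound 3 by 5-bromothiophen-2-yl in place of 3,5-dichloro-2-hydroxyphenyl on a sulfonyl sulfur. Among the measured compounds shown here, no measured step touches the group on the sulfonyl sulfur, and the one step that is measured at all is unreadable, so nothing in the three values points to a direction or size for this change. Since compound 3 itself gives only a limit, compound 4 is expected to remain at a limit as well, with the step that the limit leaves unreadable from compound 3 to compound 4 expected to be without readable size. The estimate for compound 4 in this assay is 60000 nM, within a range from 25000 nM to 150000 nM.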

Compound 4, half-maximal effective concentration: > 48200 nM
Compound 4 gave a limit, no number (the forecaster's own chance of this, stated with the estimate: 85%); the middle value is on the limit's open side.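

In this assay compound 4 gives > 48200 nM, a limit of the assay and not a number. Compound 1, compound 2 and compound 3 also sit at limits, so none of their steps to compound 4 can be read. The compounds shown leave open whether any group on the sulfonyl sulfur or the aromatic nitrogen changes the read-out in this assay, and by how much.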